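Adding one chain carbon in two related series

The source may report more compounds than this note shows. Statements on the series, on what has been measured and on what is new or still open speak of the compounds shown alone.

Compound 1 `CCCCCCc1ccc2nc(N)sc2c1` and compound 2 `CCCCCCCc1ccc2nc(N)sc2c1` share one core, and compound 3 `CCCn1c(=N)sc2cc(OC(F)(F)F)ccc21` and compound 4 `CCCCn1c(=N)sc2cc(OC(F)(F)F)ccc21` share another; how the two cores differ is not broken down here. In a functional assay on the whole organism with Rattus norvegicus as the target (on this read-out lower numbers stand for an effect already at smaller amounts and higher numbers for an effect only at larger amounts of compound), compound 1 gives 7 mg/kg. Compound 2 gives only a limit of the assay, > 10 mg/kg. The change methyl in place of hydrogen on a saturated chain carbon, six bonds along the chain from an aromatic carbon produced an at least 1.4-fold higher number from compound 1 to compound 2 (0.15 log units; that floor lies within the scatter). In this assay compound 3 gives 4.5 mg/kg. Compound 4 is not yet measured and differs from compound 3 by methyl in place of hydrogen on a saturated chain carbon, three bonds along the chain from an aromatic nitrogen, the same kind of change, though here three bonds along the chain from an aromatic nitrogen rather than six bonds along the chain from an aromatic carbon. The expected step, resting on an at least 1.4-fold higher number from compound 1 to compound 2 (0.15 log units; that floor lies within the scatter) and on compound 2 sitting at the limit of > 10 mg/kg in this assay, at which 1 of the 3 values shown sits, is a 1.4-fold higher number from compound 3 to compound 4 (0.16 log units; within the scatter). For compound 4 the estimated value is 6.5 mg/kg, between 3.5 mg/kg and 12 mg/kg.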

Compound 4, dose for half-maximal effect: 10 mg/kg
Beside the measured number, compound 4's estimate is 1.5-fold (0.19 log units) below it, and the stated range covers the measured number.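

Going from propyl to butyl in this assay gives a 2.2-fold higher number from compound 3 to compound 4 (0.35 log units; beyond the scatter), so on the core of compound 3 this single added methyl is a modest step that stands clear of the usual scatter. The value of compound 2, > 10 mg/kg, is a limit of the assay and not a number. The size of the step on the core of compound 1 therefore stays unknown, and this pair cannot show whether the change carries over from one core to the other with the same size: the same change on two cores in this assay, an at least 1.4-fold higher number (0.15 log units; that floor lies within the scatter) from compound 1 to compound 2 and a 2.2-fold higher number (0.35 log units; beyond the scatter) from compound 3 to compound 4; the limit leaves it open whether they differ

From the compounds shown here alone, it remains open how a chain longer than butyl on the core of compound 3 would read in this assay. A chain carrying an amine or a carboxylic acid is also left open on either core.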